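Removing one chloro from the benzylidene of a urea hydrazone

This account rests on a few compounds, and the source may have more. Where it says the series, first, only, none or still open, it means among the compounds named here.

Measured so far:
Compound 1 `CN(C)CCn1cnnc1-c1cc(Oc2ccc(NC(=O)N/N=C/c3ccc(Cl)cc3Cl)cc2F)ccn1`: 2330 nM
Compound 2 `CN(C)CCn1cnnc1-c1cc(Oc2ccc(NC(=O)N/N=C/c3ccccc3)cc2F)ccn1`: 2250 nM

In a functional assay on U-87MG ATCC cells (Homo sapiens) for cytotoxicity, read by MTT assay, with a stated time of 72 h (on this read-out higher numbers stand for weaker inhibition and lower numbers for stronger inhibition), compound 1 gives 2330 nM, the higher of the two numbers, though compound 2 gives 2250 nM and the two values fall within the scatter of each other. The step of a 1.0-fold lower number from compound 1 to compound 2 (0.02 log units; within the scatter) removes both chloro groups at once and still leaves the read-out essentially unchanged.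

Compound 3 `CN(C)CCn1cnnc1-c1cc(Oc2ccc(NC(=O)N/N=C/c3ccc(Cl)cc3)cc2F)ccn1` has not yet been measured. It differs from compound 1 by hydrogen in place of chloro on an aromatic carbon. Within the data shown here, the one measured step that bears on this change is a 1.0-fold lower number from compound 1 to compound 2 (0.02 log units; within the scatter), which covered a larger removal than the one considered here and stayed within the scatter. On that basis compound 3 is expected to sit close to compound 1, with a step of a 1.0-fold lower number from compound 1 to compound 3 (0.01 log units; within the scatter) that is not expected to exceed the scatter. Compound 3 is therefore estimated at 2300 nM, within a range of 1200 nM to 4600 nM.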

Compound 3, half-maximal inhibitory concentration: 1370 nM
Beside the measured number, compound 3's estimate is 1.7-fold (0.23 log units) above it; low and high end bracket the measured number.
By their numbers in this assay, from the lowest: compounds 3, 2 and 1 (each within the scatter of the next).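

In this assay, the change from 2,4-dichlorophenyl to 4-chlorophenyl, with hydrogen in place of the chloro ortho to a large group, gives a 1.7-fold lower number from compound 1 to compound 3 (0.23 log units; within the scatter) and so removes a single chloro where the earlier step had removed both. Going the other way, chloro in place of hydrogen on the unsubstituted phenyl gives a 1.6-fold lower number from compound 2 to compound 3 (0.22 log units; within the scatter) and is likewise a single change, so that neither single-chloro step passes the scatter and the read-out does not separate phenyl, 4-chlorophenyl and 2,4-dichlorophenyl. No measurement is available that could explain these values.

As far as these compounds go, whether a methoxy group, an amine or a carboxylic acid on this ring would give a step beyond the scatter stays open. The compounds shown vary only hydrogen and chloro here, so they say nothing about any other group at this position.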